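Halogen Swap on the Phenoxy Ring, Ortho Versus Meta

The compounds below may be only part of what the source reports. "The series", "measured", "known", "first", "only" and "open" are said of these compounds alone.

Three measured compounds share one core and differ only in the halogenated phenoxy group at the end of the propoxy chain. Compound 1 `NC1=NC2(CCOCC2)N(OCCCOc2ccccc2Cl)C(N)=N1` carries a 2-chlorophenoxy group, and in an assay on isolated protein for inhibition of Dihydrofolate reductase (Homo sapiens), read by spectrophotometry, using NADPH, with stated times of 5 s and 6 min, tested at 50 uM (on this read-out higher numbers stand for a stronger effect at the one concentration tested and lower numbers for a weaker effect), compound 1 gives 88.2%. Compound 2 `NC1=NC2(CCOCC2)N(OCCCOc2ccccc2Br)C(N)=N1` carries a 2-bromophenoxy group, and in this assay compound 2 gives 85%. Compound 3 `NC1=NC2(CCOCC2)N(OCCCOc2cccc(Br)c2)C(N)=N1` carries a 3-bromophenoxy group, and in this assay compound 3 gives 85.8%. The change from compound 2 to compound 3, (3-bromophenyl in place of 2-bromophenyl on an oxygen on a saturated carbon), made a step of a number 0.8 percentage points higher from compound 2 to compound 3 (within the scatter). From compound 1 to compound 3 the step was a number 2.4 percentage points lower from compound 1 to compound 3 (within the scatter). No step among these three leaves the scatter, so none of them can be set above or below another.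

The change that leads to the unmeasured compound 4 `NC1=NC2(CCOCC2)N(OCCCOc2cccc(Cl)c2)C(N)=N1` is chloro in place of bromo on an aromatic carbon. It has been made once already, from compound 2 to compound 1 as chloro in place of bromo on an aromatic carbon, where it gave a step of a number 3.2 percentage points higher from compound 2 to compound 1 (within the scatter). In compound 4 the same kind of change, (chloro in place of bromo on an aromatic carbon), is made meta to a large group rather than ortho to a large group, so it is the same kind of change but not the same one. Because a number 3.2 percentage points higher from compound 2 to compound 1 (within the scatter) stayed within the scatter, compound 4 is expected to move from compound 3 by a number 1.2 percentage points higher from compound 3 to compound 4 (within the scatter), a step of comparably small size. Resting on the value of compound 3, 85.8%, compound 4 is estimated at 87% in this assay, with a likely range from 78% to 94%.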

Compound 4, a percentage reported as inhibition, at one concentration (the size of the read-out at that concentration, not a potency): 85.8%
Compound 4: the middle estimate sits 1.2 percentage points above what was measured; the range from low to high includes it.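

In this assay the change from 3-bromophenoxy to 3-chlorophenoxy gave no change at the digits printed from compound 3 to compound 4 (within the scatter), and the two other steps that end at the new compound are equally small, a number 0.8 percentage points higher from compound 2 to compound 4 (within the scatter) and a number 2.4 percentage points lower from compound 1 to compound 4 (within the scatter). Set beside the earlier exchange of the same two halogens, the swap behaves alike in both settings, with no difference that can be told from the scatter: the same change on two cores in this assay, a number 3.2 percentage points higher (within the scatter) from compound 2 to compound 1 and no change at the digits printed (within the scatter) from compound 3 to compound 4, 3.2 percentage points apart, within the scatter of two such steps This shows that chloro in place of bromo left the read-out within the scatter in both pairs, but the read-out is the size of an effect at one concentration and not a potency, so it does not show that the two halogens are equal in potency, and two pairs do not establish how the change would behave on other cores.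

All the compounds shown keep a chloro or bromo group on the phenoxy ring and the same propoxy chain, so it remains open what a fluoro group, a nitrile, a carboxylic acid or a longer chain would give in this assay. Also open, on these data alone, is whether these compounds would separate from one another at lower concentrations.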